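Working notes: phenethyl in place of 4-(trifluoromethyl)phenyl

A few compounds are considered here, and "the series" means these few. Any claim that something is new, unique, unknown or untested is made for them only; others in the source may bear on it.

Measured in a physicochemical assay for solubility, with a stated time of 18 h, at pH 7.4; a lower number here means a less soluble compound, a higher number a more soluble compound:
- compound 1 `COc1ccc(-c2ccc3c(NCCCNCc4cccc(OC)c4O)ccnc3c2)cc1` gives 32000 nM
- compound 2 `COc1ccccc1Oc1ccc2c(NCCCNCc3cccc(OC)c3O)ccnc2c1` gives 14500 nM
- compound 3 `COc1cccc(CNCCCNc2ccnc3cc(-c4ccc(C(F)(F)F)cc4)ccc23)c1O` gives 32000 nM

Compound 3 stands level with compound 1 , and together they hold the highest of the three numbers. Compound 4 `COc1cccc(CNCCCNc2ccnc3cc(CCc4ccccc4)ccc23)c1O` is still to be measured, with this change: phenethyl in place of 4-(trifluoromethyl)phenyl on an aromatic carbon. For the measured compounds named here, three steps bear on it. There is no change at the digits printed from compound 1 to compound 3 (within the scatter), while a 2.2-fold lower number from compound 1 to compound 2 (0.34 log units; beyond the scatter) and a 2.2-fold higher number from compound 2 to compound 3 (0.34 log units; beyond the scatter) are both modest. Going by the values given here, no measured compound carries phenethyl, so no step tests it directly. A small downward move is therefore expected, with a 1.5-fold lower number from compound 3 to compound 4 (0.16 log units; within the scatter) as the estimated step. Compound 4 is expected at 22000 nM, with an estimated range of 11000 nM to 36000 nM.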

Compound 4, solubility: 4200 nM
The estimate for compound 4 lay 5.2-fold (0.72 log units) above the measured number; measured number below the stated range.
By their numbers in this assay, from the lowest: compound 4; then compound 2; then compounds 1 and 3 (each within the scatter of the next).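

In this assay, for the compounds shown here, this aromatic carbon proves more sensitive than the earlier compounds suggested: their widest gap was a 2.2-fold higher number from compound 2 to compound 3 (0.34 log units; beyond the scatter), whereas phenethyl gives a 7.6-fold lower number from compound 3 to compound 4 (0.88 log units; beyond the scatter) and a 7.6-fold lower number from compound 1 to compound 4 (0.88 log units; beyond the scatter), as well as a 3.5-fold lower number from compound 2 to compound 4 (0.54 log units; beyond the scatter). Compound 4 therefore holds the lowest number of the four, and the series now spans a wider range through this one position. Nothing available accounts for the drop. As far as these compounds go, whether a benzyl group, a longer phenylpropyl chain or an amine on the phenethyl ring would restore the number remains open.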